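The source may report more compounds than this note shows. Statements on the series, on what has been measured and on what is new or still open speak of the compounds shown alone.

Measured compounds in this series:

compound 1 `Cc1ccc(NC(=O)N[C@@H](C)c2ccccc2)cc1` — in an ADME assay on the whole organism with Oryza sativa as the target, tested at 1 uM (on this read-out lower numbers stand for a stronger effect and higher numbers for a weaker effect at the one concentration tested), compound 1 gives 99%
compound 2 `C[C@@H](NC(=O)Nc1ccc(F)cc1F)c1ccccc1` — in this assay compound 2 gives 100%
compound 3 `C[C@H](NC(=O)Nc1ccc(F)cc1F)c1ccccc1` — in this assay compound 3 gives 100%

Compound 3 stands level with compound 2 in this assay, and together they hold the highest readings of the three; the reading of compound 1 lies within the scatter of both, so no order among the three can be drawn. Among the measured compounds shown here, the only measured step, no change at the digits printed from compound 2 to compound 3 (within the scatter), stays within the scatter, and it rests on (the fact that compounds 2 and 3 differ only in the configuration as drawn), so it says nothing about substituent exchange on the aromatic ring.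

Compound 4 `Cc1ccc(NC(=O)N[C@@H](C)c2ccccc2)c(F)c1` differs from compound 3 in one place: methyl in place of fluoro on an aromatic carbon. For the measured compounds named here, no measured step covers a methyl-for-fluoro exchange, so the expectation rests only on the narrow band of the three readings. Compound 4 is expected to give an estimated reading of 98% in this assay, between 86% and 100%. The step of a number 2 percentage points lower from compound 3 to compound 4 (within the scatter) is expected to remain within the scatter, with the upper end capped by the scale.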

Compound 4, a percentage reported as activity, at one concentration (the size of the read-out at that concentration, not a potency): 99%
Compound 4: the middle estimate sits 1 percentage points below what was measured, and the stated range covers the measured number.
By their numbers in this assay, from the lowest: compounds 1, 4, 2 and 3 (each within the scatter of the next).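

In this assay, methyl and fluoro on this aromatic carbon, para to a large group, are not told apart: the exchange gives a number 1 percentage points lower from compound 3 to compound 4 (within the scatter). Adding fluoro in place of hydrogen on an aromatic carbon of the methyl-bearing ring is equally silent, with no change at the digits printed from compound 1 to compound 4 (within the scatter), so neither single change to the aromatic substituents shifts the reading at the one concentration tested. Nothing available bears on why these readings coincide.

As far as these compounds go, whether an amine, a carboxylic acid or a nitrile on this aromatic carbon would shift the reading remains open. Also open, from the compounds shown here alone, is whether any change to the shared core, such as a longer chain on the saturated carbon carrying the methyl, would move the number beyond the scatter.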